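The source may hold more compounds than are shown below. What is called first, only, known or untested is meant among the compounds shown, and "the series" means these compounds.

Going by the values given here, compound 1 `CCCc1nc2c(C)cc(-c3nc4ccccc4n3C)cc2n1S(=O)(=O)c1c(C)cc(C)cc1C` is the only member of this set with a definite number in a functional assay on HeLa cells (Homo sapiens) for cytotoxicity, read by MTT assay; on this read-out lower numbers stand for stronger inhibition and higher numbers for weaker inhibition; in this assay compound 1 gives 21000 nM. Compound 2 `CCCc1nc2c(C)cc(-c3nc4ccccc4n3C)cc2n1S(=O)(=O)c1ccccc1Cl` reaches only a limit of the assay, > 50000 nM. Compound 2 sits at the limit of > 50000 nM in this assay, at which 1 of the 2 values shown sits. The measured step of an at least 2.3-fold higher number from compound 1 to compound 2 (0.37 log units; beyond the scatter) points toward weaker inhibition. Compound 3 `CCCc1nc2c(C)cc(-c3nc4ccccc4n3C)cc2n1S(=O)(=O)c1ccccc1Br` differs from compound 1 by 2-bromophenyl in place of 2,4,6-trimethylphenyl on a sulfonyl sulfur. Among the compounds with values here, this change resembles the one from compound 1 to compound 2, so a step of at least modest size toward a higher number is expected in this assay. Compound 3 is therefore estimated at 60000 nM, within 25000 nM to 150000 nM. The estimated step is a 2.9-fold higher number from compound 1 to compound 3 (0.46 log units; beyond the scatter).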

Compound 3, half-maximal inhibitory concentration: > 50000 nM
Compound 3: no number, only a limit; the forecaster's own chance of this, stated with the estimate: 60%; the middle value lies beyond the limit too.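

Replacing 2,4,6-trimethylphenyl with 2-bromophenyl on a sulfonyl sulfur gives an at least 2.3-fold higher number from compound 1 to compound 3 (0.37 log units; beyond the scatter), so in this assay the weaker inhibition is no longer seen with the 2-chlorophenyl group of compound 2 alone. The step from compound 2 to compound 3 cannot be read, because both compounds end at the same limit: the limit of > 50000 nM in this assay, at which 2 of the 3 values shown sit.

The compounds shown leave open whether bromo and chloro differ at all here, and how a methoxy group or an amine in place of the bromo would read in this assay.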